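Replacing a Benzoyl with a 4-Fluorophenyl: Expected Cytotoxicity

The source may hold more compounds than are shown below. What is called first, only, known or untested is meant among the compounds shown, and "the series" means these compounds.

The study rests on a functional assay on Raji cells (Homo sapiens) for cytotoxicity, with a stated time of 72 h; on this read-out higher numbers stand for an effect only at larger amounts of compound and lower numbers for an effect already at smaller amounts. Compound 1 `C=C[C@@](C)(/C=C/c1ccc(OS(=O)(=O)C(F)(F)F)cc1)CCC=C(C)C` gives in this assay only a limit, > 26000 nM. Compound 2 `C=C[C@@](C)(/C=C/c1ccc(O)c(/C=C/C(=O)c2ccccc2)c1)CCC=C(C)C` likewise gives in this assay only a limit, > 26000 nM. Both measured compounds therefore stand at the same boundary, (the limit of > 26000 nM in this assay, at which 2 of the 2 values shown sit), and neither shows an effect within the tested range of amounts. Among the measured compounds shown here, no step between the two measured compounds is given, and their two limits show only that both lie beyond what the assay resolves.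

Compound 3 `C=C[C@@](C)(/C=C/c1ccc(O)c(/C=C/c2ccc(F)cc2)c1)CCC=C(C)C` has not been measured. It differs from compound 2 in one place: 4-fluorophenyl in place of benzoyl on a double-bonded chain carbon bound to a double-bonded chain carbon. The carbonyl of the benzoyl is lost, and a ring carrying fluorine takes its place.

With both measured compounds at the limit, no step beyond the scatter is expected in this assay, and the expected step is a step that the limit leaves unreadable from compound 2 to compound 3. Compound 3 is estimated at 40000 nM in this assay, within a range from 10000 nM to 150000 nM, and it is expected most likely to be reported again only as a limit.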

Compound 3, half-maximal effective concentration: > 26000 nM
Compound 3 was reported as a limit; the forecaster's own chance of this, stated with the estimate: 70%; the middle value is on the limit's open side.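

Compound 3 gives in this assay only a limit, > 26000 nM. No step can therefore be read from compound 2 to compound 3, since both sit at the same boundary: the limit of > 26000 nM in this assay, at which 3 of the 3 values shown sit.

The compounds shown leave open whether 4-fluorophenyl in place of benzoyl changes cytotoxicity, and at what amount any of them would show an effect.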